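The source may hold more compounds than are shown below. What is called first, only, known or untested is meant among the compounds shown, and "the series" means these compounds.

Measured compounds:
- Compound 1 `O=C(Nc1ccc(F)cc1)N1N=C(c2ccc(Br)cc2)CC1c1ccc(F)cc1`. In an assay on HEK293 cells for inhibition of Voltage-dependent L-type calcium channel subunit alpha-1C (Homo sapiens), read by FLIPR and calcium flux, with a stated time of 3 min (a lower number here means a stronger inhibitor, a higher number a weaker inhibitor), compound 1 gives > 10000 nM, which is a limit of the assay rather than a number.
- Compound 2 `CC(C)NC(=O)N1N=C(c2ccc(Br)cc2)CC1c1ccc(F)cc1`. In this assay compound 2 gives 2360 nM.
- Compound 3 `COCC1(c2ccc(C)cc2)CC(c2ccccc2)=NN1C(=O)Nc1ccc(F)cc1`. In this assay compound 3 gives > 10000 nM, again only a limit of the assay.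

Compound 3 therefore stands at the limit of > 10000 nM in this assay, at which 2 of the 3 values shown sit, with no number of its own. The next compound, compound 4 `Cc1ccc(C2(CCN(C)C)CC(c3ccccc3)=NN2C(=O)Nc2ccc(F)cc2)cc1`, carries (dimethylamino)methyl in place of methoxy on a saturated chain carbon bound to a saturated ring carbon. Going by the values given here, the only measured step in the set, an at least 4.2-fold lower number from compound 1 to compound 2 (0.62 log units; beyond the scatter), concerns the amide-type nitrogen, a different place, so no measured step bears on this change. No step beyond the scatter is expected in this assay, and compound 4 is estimated at 10000 nM, range 3000 nM to 30000 nM, which means an expected step of a number no higher from compound 3 to compound 4 (the limit leaves the size open). A limit rather than a number is again expected for compound 4.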

Compound 4, half-maximal inhibitory concentration: 2200 nM
Estimate against measurement, compound 4: 4.5-fold (0.66 log units) above, outside the stated range (below it).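

At this place, on a saturated chain carbon bound to a saturated ring carbon, the change from methoxymethyl to 2-(dimethylamino)ethyl gives in this assay an at least 4.5-fold lower number from compound 3 to compound 4 (0.65 log units; beyond the scatter). The set thus gains a second site that responds, apart from the amide-type nitrogen, and it does so with 4-fluorophenyl kept on that nitrogen. The true size of the step stays open because compound 3 has only a limit of the assay: the limit of > 10000 nM in this assay, at which 2 of the 4 values shown sit.

The nitrogen and the longer chain enter together, and the compounds shown do not separate them. A plain butyl chain or a carboxylic acid at this place would bear on that question.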